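The source may report more compounds than this note shows. Statements on the series, on what has been measured and on what is new or still open speak of the compounds shown alone.

Compound 1 `COc1cc(O)c([C@@H](/C=C/c2ccc(O)cc2)CCCCc2ccc(O)cc2)c(O)c1C(=O)/C=C/c1ccc(O)cc1`: 27.4 uM; compound 2 `COc1cc(O)c([C@@H]2C[C@H](CCc3ccc(O)cc3)O[C@@H](c3ccc(O)cc3)C2)c(O)c1C(=O)/C=C/c1ccc(O)cc1`: 0.89 uM.

In a functional assay on cells (Mus musculus) for cytotoxicity, read by MTT assay (a lower number here means that less compound is needed, a higher number that more compound is needed for the effect), compound 1 gives the highest of the two numbers; compound 2 sits a good deal lower, and that gap is beyond the scatter. Compound 3 `COc1cc(O)c([C@@H](/C=C/c2ccc(O)cc2)C[C@@H](O)CCc2ccc(O)cc2)c(O)c1C(=O)/C=C/c1ccc(O)cc1` is not yet measured. It differs from compound 1 by hydroxy in place of hydrogen on a saturated chain carbon bound to two saturated chain carbons. Within the data shown here, no single-point step between measured compounds exists to guide the size of this change, so the step from compound 1 to compound 3 is expected to be modest, leaning toward a lower number but possibly within the scatter: a 1.8-fold lower number from compound 1 to compound 3 (0.26 log units; within the scatter). Compound 3 is therefore estimated at 15 uM, with a range from 4 uM to 50 uM.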

Compound 3, concentration for half-maximal effect: 13.1 uM
Beside the measured number, compound 3's estimate is 1.1-fold (0.06 log units) above it; the range from low to high includes it.
By their numbers in this assay, from the lowest: compound 2; then compound 3; then compound 1.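

In this assay, hydroxy in place of hydrogen on a saturated chain carbon bound to two saturated chain carbons gives a 2.1-fold lower number from compound 1 to compound 3 (0.32 log units; beyond the scatter), so the number responds to this change at this position, though the step is modest. Among these compounds, it is the only step here between compounds differing in one place, so its size cannot be set against another. No measurement on hand explains the step.

As far as these compounds go, whether an amine or a methoxy on this carbon would give a similar step stays open. So does the effect of the opposite configuration of the hydroxy-bearing carbon.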